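From Thiomorpholine to Piperidine on the Thiocarbonyl Carbon

The source may report more compounds than this note shows. Statements on the series, on what has been measured and on what is new or still open speak of the compounds shown alone.

Two compounds of this series have numbers in a functional assay on MCF7 cells (Homo sapiens) for cytotoxicity, read by MTT assay, with a stated time of 72 h; on this read-out lower numbers stand for stronger inhibition and higher numbers for weaker inhibition. Compound 1 `N/C(=N\NC(=S)N1CCCC1)c1ccc(F)cn1` carries a pyrrolidine on its thiocarbonyl carbon, and in this assay compound 1 gives 900 nM. Compound 2 `Cc1cccc(/C(N)=N/NC(=S)N2CCSCC2)n1` has a different core and a thiomorpholin-4-yl group on the thiocarbonyl carbon. For compound 2 this assay reports no number but only a limit, > 100000 nM. That limit is where one of the two values stands (the limit of > 100000 nM in this assay, at which 1 of the 2 values shown sits), so compound 2 can only be placed as weak, without a measured figure.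

Compound 3 `Cc1cccc(/C(N)=N/NC(=S)N2CCCCC2)n1` keeps the core of compound 2 and differs in a single place: piperidin-1-yl in place of thiomorpholin-4-yl on a thiocarbonyl carbon. For the measured compounds named here, no pair of measured compounds shows this exact exchange, so nothing here tells how large a step it causes. With only a limit to start from, the step from compound 2 to compound 3 is expected to be a number no higher from compound 2 to compound 3 (the limit leaves the size open), which is within the usual scatter. Compound 3 is therefore expected to give about 100000 nM, somewhere from 20000 nM to 300000 nM, and may again return only a limit.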

Compound 3, half-maximal inhibitory concentration: 74000 nM
Beside the measured number, compound 3's estimate is 1.4-fold (0.13 log units) above it; measured number inside the range.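

In this assay, for the compounds shown here, compound 3 gives 74000 nM, which is the first real number on the core of compound 2 and shows that a group on this thiocarbonyl carbon can return a measured figure on that core. The exchange of thiomorpholin-4-yl for piperidin-1-yl, two six-membered rings that differ in that the first holds a sulfur where the second holds a carbon, amounts to an at least 1.3-fold lower number from compound 2 to compound 3 (0.13 log units; that floor lies within the scatter), so the data show no more than a small step that cannot be told apart from scatter. The end of the step at compound 2 is a limit and not a number, so the true size of the step stays open: the limit of > 100000 nM in this assay, at which 1 of the 3 values shown sits.

The compounds shown leave open how a morpholine ring, with oxygen in place of the sulfur, or an open-chain dimethylamino group would behave on this thiocarbonyl carbon. Compound 1 differs from compound 3 in more than one place, so these compounds cannot say how much of the difference between their values belongs to the ring on the thiocarbonyl carbon and how much to the core.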